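Aryl exchange on compound 3

This account rests on a few compounds, and the source may have more. Where it says the series, first, only, none or still open, it means among the compounds named here.

In a functional assay on A549 cells (Homo sapiens) for antiproliferative activity, read by MTT assay, with a stated time of 72 h (on this read-out lower numbers stand for stronger inhibition and higher numbers for weaker inhibition), compound 1 `Cc1ccc(-c2noc(CCCCCCC(=O)NO)n2)cc1` gives 5810 nM while compound 2 `O=C(CCCCCCc1nc(-c2cccnc2)no1)NO` gives 5340 nM and compound 3 `Cc1ccc(-c2noc(CCCCCCC(=O)Nc3ccccc3N)n2)cc1` gives 9170 nM with all three values within the scatter of each other. Compound 4 `Nc1ccccc1NC(=O)CCCCCCc1nc(-c2ccccc2Cl)no1` has 2-chlorophenyl in place of 4-methylphenyl on an aromatic carbon of the shared core: 2-chlorophenyl in place of 4-methylphenyl on an aromatic carbon The closest measured change is an exchange at the same carbon, with a 1.1-fold lower number from compound 1 to compound 2 (0.04 log units; within the scatter) for a different entering group. The change on the amide-type nitrogen, with a 1.6-fold higher number from compound 1 to compound 3 (0.20 log units; within the scatter) as its size, bears on it less directly. Among the compounds with values here, no 2-chlorophenyl compound has been measured yet. The expected step is a 1.1-fold lower number from compound 3 to compound 4 (0.06 log units; within the scatter) and no shift beyond the scatter is expected. For compound 4 the estimate is 8000 nM with an expected range from 3500 nM to 18000 nM in this assay as read here.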

Compound 4, half-maximal inhibitory concentration: > 100000 nM
Compound 4: no number, only a limit (the forecaster's own chance of this, stated with the estimate: 5%); middle value at least 12-fold (1.09 log units) from the limit.
By their numbers in this assay, from the lowest: compounds 2, 1 and 3 (each within the scatter of the next). At a limit, above all of these: compound 4.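

Compound 4 has no number in this assay, only a limit: the limit of > 100000 nM in this assay, at which 1 of the 4 values shown sits. At this aromatic carbon, between two ring nitrogen atoms, 2-chlorophenyl in place of 4-methylphenyl gives an at least 10-fold higher number from compound 3 to compound 4 (1.03 log units; beyond the scatter), whereas the earlier exchange at the same carbon, a 1.1-fold lower number from compound 1 to compound 2 (0.04 log units; within the scatter), stayed within the scatter. The position is therefore not indifferent to the aryl group, at least with 2-aminophenyl on the amide-type nitrogen.

Still open, as far as these compounds go, is whether 4-chlorophenyl or unsubstituted phenyl at this carbon would read like 2-chlorophenyl or like 4-methylphenyl. Also open, from the compounds shown here alone, is whether 2-chlorophenyl has the same effect with hydroxy on the amide-type nitrogen.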